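Swapping the pyridine for a fluorophenyl on the core

The source may hold more compounds than are shown below. What is called first, only, known or untested is meant among the compounds shown, and "the series" means these compounds.

Compound 2 `O=S(=O)(Nc1ccc(F)c(C#Cc2cnc3[nH]nc(-c4ccncc4)c3c2)c1F)c1cccnc1` carries a pyridin-4-yl group on the shared core. In a functional assay on HCT-116 cells (Homo sapiens) for antiproliferative activity, read by MTT assay, with a stated time of 68 h (on this read-out higher numbers stand for weaker inhibition and lower numbers for stronger inhibition), compound 2 gives only a limit, > 10000 nM, and no number. Its neighbour compound 1 `O=S(=O)(Nc1ccc(F)c(C#Cc2cnc3[nH]nc(C4CC4)c3c2)c1F)c1cccnc1` bears a cyclopropyl group in the same position, and in this assay compound 1 gives 584 nM. For the measured compounds named here, the only measured step, an at least 17-fold higher number from compound 1 to compound 2 (1.23 log units; beyond the scatter), is large, and it rests on the limit of > 10000 nM in this assay, at which 1 of the 2 values shown sits, rather than on a finished number. Compound 3 `O=S(=O)(Nc1ccc(F)c(C#Cc2cnc3[nH]nc(-c4ccc(F)cc4)c3c2)c1F)c1cccnc1` is the unmeasured partner: 4-fluorophenyl in place of pyridin-4-yl on an aromatic carbon. Going by the values given here, no measured step separates a pyridin-4-yl group from a 4-fluorophenyl group, so the data give no direction for this change; the one large step shows only that a cyclopropyl group sits well below the pyridin-4-yl limit. Compound 3 is therefore expected near the limit region, with the step of an at least 2.0-fold lower number from compound 2 to compound 3 (0.30 log units; that floor lies within the scatter) estimated, and wide uncertainty. Compound 3 is estimated at 5000 nM, between 1000 nM and 20000 nM.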

Compound 3, half-maximal inhibitory concentration: > 10000 nM
Compound 3: no number, only a limit; the forecaster's own chance of this, stated with the estimate: 40%; middle value at least 2.0-fold (0.30 log units) away from the limit.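

The loss seen with pyridin-4-yl is not confined to that group, since 4-fluorophenyl on the same aromatic carbon, which has no ring nitrogen, also departs sharply from cyclopropyl in this assay, with an at least 17-fold higher number from compound 1 to compound 3 (1.23 log units; beyond the scatter). The step between compound 2 and compound 3 cannot be read, as both values are limits and not numbers. Any reading of this position therefore rests on the contrast with cyclopropyl and on one ceiling: the limit of > 10000 nM in this assay, at which 2 of the 3 values shown sit.

As far as these compounds go, how far either six-membered aromatic ring lies beyond that limit remains open, and so does any order between the two. From the compounds shown here alone, it is also open whether a methyl group, an ethyl chain or an amine on this carbon would keep, lose or improve on the value of compound 1, 584 nM.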